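This account rests on a few compounds, and the source may have more. Where it says the series, first, only, none or still open, it means among the compounds named here.

Compound 1 `CCOC(=O)CSc1nnc(C)n1N1C(=O)c2ccccc2C1=O` — in a functional assay on A549 cells (Homo sapiens) for cytotoxicity, read by MTT assay, with a stated time of 48 h (a lower number here means a stronger inhibitor, a higher number a weaker inhibitor), compound 1 gives > 200000 nM, which is a limit of the assay and not a number.
Compound 2 `Cc1nnc(SCC(=O)c2ccc(Cl)cc2)n1N1C(=O)c2ccccc2C1=O` — in this assay compound 2 gives > 200000 nM, which is likewise a limit and not a number.

Compound 2 therefore stands at the edge of what this assay reports, and nothing sets it apart from compound 1: both values sit at the limit of > 200000 nM in this assay, at which 2 of the 2 values shown sit. Among the compounds with values here, the one step between measured compounds, a step that the two limits leave unreadable from compound 1 to compound 2, is left unreadable by the two limits, so no size can be attached to it.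

Compound 3 `Cc1ccc(C(=O)CSc2nnc(C)n2N2C(=O)c3ccccc3C2=O)cc1` differs from compound 2 in one place: methyl in place of chloro on an aromatic carbon. Within the data shown here, because the only step that could bear on this change, a step that the two limits leave unreadable from compound 1 to compound 2, is unreadable, there is no measured basis for expecting either a gain or a loss here. Since compound 2 sits at the limit of > 200000 nM in this assay, at which 2 of the 2 values shown sit, the expectation for compound 3 is that it too stays at or beyond the limit rather than moving into the readable range. Compound 3 is therefore estimated at 250000 nM, with a range from 100000 nM to 600000 nM, which corresponds to an expected step that the limit leaves unreadable from compound 2 to compound 3.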

Compound 3, half-maximal inhibitory concentration: > 200000 nM
Compound 3: a limit, no number; the forecaster's own chance of this, stated with the estimate: 85%; the middle value does not contradict the limit.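

In this assay compound 3 gives > 200000 nM, which is a limit and not a number. No new step can be read among compound 1, compound 2 and compound 3: the limit of > 200000 nM in this assay, at which 3 of the 3 values shown sit. The compounds shown leave open how large the change from chloro to methyl really is, and whether any change to the shared core gives a readable value.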